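Working notes on a styryl series: compounds 1 to 3

The source may hold more compounds than are shown below. What is called first, only, known or untested is meant among the compounds shown, and "the series" means these compounds.

Measured compounds:
Compound 1 `COc1ccc(Nc2nc(/C=C/c3ccccc3)nc3ccsc23)cc1` in a functional assay on L02 cells (Homo sapiens) for inhibition, read by Griess assay, with stated times of 1 h and 24 h (on this read-out higher numbers stand for weaker inhibition and lower numbers for stronger inhibition), gives > 1000000 nM, a limit of the assay.
Compound 2 `COc1cc(/C=C/c2nc(N(C)C)c3sccc3n2)cc(OC)c1OC` in this assay gives > 1000000 nM, likewise a limit and not a number.

Within the data shown here, compound 2 therefore stands at the limit, and so does the only other value shown: the limit of > 1000000 nM in this assay, at which 2 of the 2 values shown sit. Neither compound is placed relative to the other; the two values show only that both lie at the limit. Among the measured compounds shown here, no step between measured compounds can be computed.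

Compound 3 `COc1cc(/C=C/c2nc(Nc3ccc(C(F)(F)F)cc3)c3sccc3n2)cc(OC)c1OC` is not yet measured in this assay. It differs from compound 2 in one place: (4-(trifluoromethyl)phenyl)amino in place of dimethylamino on an aromatic carbon. A related arylamino group is carried by compound 1, whose value is also a limit, so the shown data give no foothold for a change beyond the scatter in either direction. For the measured compounds named here, the expected step from compound 2 to compound 3 is an at least 1.4-fold lower number from compound 2 to compound 3 (0.15 log units; that floor lies within the scatter), that is, no step that can be told apart from a limit. For compound 3 in this assay the estimate is 700000 nM, ranging from 50000 nM to 3000000 nM, with a high chance that only a limit is reported again.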

Compound 3, half-maximal inhibitory concentration: 436000 nM
Compound 3: the middle estimate sits 1.6-fold (0.21 log units) above what was measured, within the range that was stated.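

Among these compounds, compound 3 gives the first value in this assay that is a number and not a limit, so a change at this position, on the six-membered aromatic ring with 2 nitrogen, can move the read-out off the limit. Putting (4-(trifluoromethyl)phenyl)amino in place of dimethylamino gives an at least 2.2-fold lower number from compound 2 to compound 3 (0.36 log units; beyond the scatter), and this is a floor and not a full size, since the step starts from a limit. Even so, inhibition in this series stays weak on the evidence shown, and most of the values still give no number: the limit of > 1000000 nM in this assay, at which 2 of the 3 values shown sit.

What remains open is which part of the entering group carries the step, since the compounds shown do not separate the amine hydrogen, the aromatic ring and the trifluoromethyl group from one another; a plain phenylamino group or a piperidine at this position would speak to that. From the compounds shown here alone, compound 1 differs from compound 3 in more than one place, so no step can be read between them, and the part played by the three methoxy groups on the styryl ring stays open as well.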